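A few compounds are considered here, and "the series" means these few. Any claim that something is new, unique, unknown or untested is made for them only; others in the source may bear on it.

Measured compounds:
- compound 1, `Cc1ccc(C2=NN(C3=NC(=O)CS3)C(c3ccc4ccccc4c3)C2)cc1` — in a functional assay on HeLa cells (Homo sapiens) for inhibition, read by CCK-8 assay, with a stated time of 48 h (a higher number here means a weaker inhibitor, a lower number a stronger inhibitor), compound 1 gives 1760 nM
- compound 2, `Cc1ccc(C2=NN(C3=NC(c4ccccc4)CS3)C(c3cccc4ccccc34)C2)cc1` — in this assay compound 2 gives 4290 nM
- compound 3, `O=C1CSC(N2N=C(c3ccc(Cl)cc3)CC2c2ccc3ccccc3c2)=N1` — in this assay compound 3 gives 6320 nM

Compound 1 and compound 3 share one core and differ in a single spot: chloro in place of methyl on an aromatic carbon. That change made a step of a 3.6-fold higher number from compound 1 to compound 3 (0.56 log units; beyond the scatter), so compound 3 is the weaker inhibitor of the two.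

Compound 2 has a different core; how its core differs from that of compound 1 is not broken down here. Its number is within the scatter of that of compound 3 and lies beyond the scatter above that of compound 1.

Compound 4, `Clc1ccc(C2=NN(C3=NC(c4ccccc4)CS3)C(c3cccc4ccccc34)C2)cc1`, has not yet been measured. It stands to compound 2 as compound 3 stands to compound 1: chloro in place of methyl on an aromatic carbon. The place of the change is described in the same words for both pairs, so this is the same change on a second core.

Among the compounds with values here, the only guide is the measured pair, in which compound 3 came out weaker than compound 1 by a 3.6-fold higher number from compound 1 to compound 3 (0.56 log units; beyond the scatter). Carrying that step over, the expectation is that compound 4 will show a number higher than that of compound 2, with an expected step of a 3.0-fold higher number from compound 2 to compound 4 (0.48 log units; beyond the scatter). On that basis compound 4 is estimated at 13000 nM in this assay, with a likely range from 5000 nM to 35000 nM.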

Compound 4, half-maximal inhibitory concentration: 9940 nM
Compound 4: middle estimate off by 1.3-fold (0.12 log units), on the high side; low and high end bracket the measured number.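

Replacing methyl with chloro on the second core again gave a weaker inhibitor in this assay, with a 2.3-fold higher number from compound 2 to compound 4 (0.36 log units; beyond the scatter). Set beside the first pair, the change moved the number in the same direction on both cores, and the two steps are no further apart than repeated measurements would be expected to scatter: the same change on two cores in this assay, a 3.6-fold higher number (0.56 log units; beyond the scatter) from compound 1 to compound 3 and a 2.3-fold higher number (0.36 log units; beyond the scatter) from compound 2 to compound 4, 1.5-fold (0.19 log units) apart, within the scatter of two such steps

In these two pairs, then, the change from 4-methylphenyl to 4-chlorophenyl carried over from one core to the other, both in direction and, within the scatter, in size, but two pairs cannot show that it would do so on every core in the series, and the numbers alone do not explain why the inhibitor becomes weaker.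

The compounds shown carry only methyl or chloro at this place on the ring, so it remains open how a fluoro group, a methoxy group, an amine or a carboxylic acid there would compare. From the compounds shown here alone, it also remains open whether the same step would appear on a third core or in cells other than those used here.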